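Swapping a sulfonylamino ester for a fluorinated aryl ester

A few compounds are considered here, and "the series" means these few. Any claim that something is new, unique, unknown or untested is made for them only; others in the source may bear on it.

Measured so far:
compound 1, `CC1=CC[C@H]2[C@@H]1CC=C(C)[C@@H](CC[C@H]1[C@]3(C)CC[C@H](OC(=O)c4ccccc4)C(C)(C)O[C@H]3CC[C@@]1(C)O)C2(C)C`: 23100 nM
compound 2, `CC1=CC[C@H]2[C@H](CC[C@]2(C)O)C(C)(C)[C@@H]1CC[C@H]1[C@]2(C)CC[C@H](OC(=O)NS(=O)(=O)c3ccc(C)cc3)C(C)(C)O[C@H]2CC[C@@]1(C)O`: only a limit

Compound 1 was tested in a functional assay on MCF7 cells (Homo sapiens) for antiproliferative activity, read by MTT assay, with a stated time of 72 h (a lower number here means a stronger inhibitor, a higher number a weaker inhibitor), and gave 23100 nM. Compound 2 reached only the limit of the measurement, > 50000 nM, so no number is known for it. Compound 2 therefore stands at the weaker edge of what this assay can report, as marked by the limit of > 50000 nM in this assay, at which 1 of the 2 values shown sits. The two structures differ in more than one place, so the two values only show that compound 1 has a measurable number and compound 2 does not.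

Compound 3, `CC1=CC[C@H]2[C@H](CC[C@]2(C)O)C(C)(C)[C@@H]1CC[C@H]1[C@]2(C)CC[C@H](OC(=O)c3ccc(C(F)(F)F)c(F)c3)C(C)(C)O[C@H]2CC[C@@]1(C)O`, keeps the whole core of compound 2 and changes only the group on the carbonyl carbon: 3-fluoro-4-(trifluoromethyl)phenyl in place of ((4-methylphenyl)sulfonyl)amino on a carbonyl carbon. Going by the values given here, no measured step matches this change, so the expected size of the move from compound 2 is uncertain. Compound 3 is expected to reach a measurable number, with a step of an at least 2.0-fold lower number from compound 2 to compound 3 (0.30 log units; that floor lies within the scatter) relative to the limit of compound 2. The estimate for compound 3 in this assay is 25000 nM, in a range from 8000 nM to 60000 nM, with a real chance that only a limit is reported again.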

Compound 3, half-maximal inhibitory concentration: > 50000 nM
Compound 3: a limit, no number; the forecaster's own chance of this, stated with the estimate: 35%; middle value at least 2.0-fold (0.30 log units) away from the limit.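

Compound 2 and compound 3 both stop at a limit rather than a number, so no step between them can be read: the limit of > 50000 nM in this assay, at which 2 of the 3 values shown sit.

The compounds shown leave open how far beyond that limit each one lies. They also leave open which of the structural differences from compound 1 goes with its measurable value of 23100 nM.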